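The source may report more compounds than this note shows. Statements on the series, on what has been measured and on what is new or still open speak of the compounds shown alone.

Measured compounds:

Compound 1, `CC(C)c1ccc(-c2nc(SCc3cn(CC(=O)NC(=O)Nc4ccccn4)nn3)nc(Nc3ccc(F)cc3)c2C#N)cc1`. In a functional assay on ECa-109 cells (Homo sapiens) for inhibition, read by MTT assay, with a stated time of 72 h (on this read-out lower numbers stand for stronger inhibition and higher numbers for weaker inhibition), compound 1 gives > 64000 nM, which is a limit of the assay rather than a number.

Compound 2, `CC(C)c1ccc(-c2nc(SCc3cn(CC(=O)NC(=O)Nc4ccccn4)nn3)nc(Nc3ccc(Cl)cc3)c2C#N)cc1`. In this assay compound 2 gives 11200 nM.

Compound 3, `CC(C)c1ccc(-c2nc(SCc3cn(CC(=O)NC(=O)Nc4ccccn4)nn3)nc(Nc3cccc(Cl)c3)c2C#N)cc1`. In this assay compound 3 gives 13300 nM.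

Compound 3 has the higher of the two numbers shown, but its nearest neighbour is compound 2, and the step of a 1.2-fold higher number from compound 2 to compound 3 (0.07 log units; within the scatter) keeps the two within the usual scatter. Compound 1 sits at the limit (the limit of > 64000 nM in this assay, at which 1 of the 3 values shown sits), so the steps of an at least 5.7-fold lower number from compound 1 to compound 2 (0.75 log units; beyond the scatter) and an at least 4.8-fold lower number from compound 1 to compound 3 (0.68 log units; beyond the scatter) are known only as lower bounds.

Compound 4, `Cc1ccccc1Nc1nc(SCc2cn(CC(=O)NC(=O)Nc3ccccn3)nn2)nc(-c2ccc(C(C)C)cc2)c1C#N`, differs from compound 3 by one change: 2-methylphenyl in place of 3-chlorophenyl on a nitrogen on an aromatic ring. Among the measured compounds shown here, none of the measured steps covers this change. For the measured compounds named here, the steps from compound 1 swap one halogen for another, and the step from compound 2 to compound 3 moves a chloro group; no step removes the halogen altogether or introduces a methyl group. The direction of the step is therefore open, and the range must be wide.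

Compound 4 is expected to give 22000 nM in this assay, with a range from 7000 nM to 64000 nM, an estimated step of a 1.7-fold higher number from compound 3 to compound 4 (0.22 log units; within the scatter).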

Compound 4, half-maximal inhibitory concentration: 7230 nM
Estimate against measurement, compound 4: 3.0-fold (0.48 log units) above, within the range that was stated.
By their numbers in this assay, from the lowest: compounds 4, 2 and 3 (each within the scatter of the next). At a limit, above all of these: compound 1.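

In this assay, 2-methylphenyl on this nitrogen carries no halogen, yet compound 4 cannot be told apart from the two chlorophenyl compounds: a 1.8-fold lower number from compound 3 to compound 4 (0.26 log units; within the scatter) and a 1.5-fold lower number from compound 2 to compound 4 (0.19 log units; within the scatter). Among compound 2, compound 3 and compound 4, a chloro group on this ring is therefore not needed for a number in this range, and a methyl group can take the place of the 3-chlorophenyl or 4-chlorophenyl ring's chloro group without a change that stands out from the scatter. Among the compounds shown here, the only new step beyond the scatter is an at least 8.8-fold lower number from compound 1 to compound 4 (0.94 log units; beyond the scatter), and it is known only as a lower bound, because compound 1 stands at a limit of the assay rather than at a number: the limit of > 64000 nM in this assay, at which 1 of the 4 values shown sits.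

Methyl and chloro never sit at the same place on this ring here, so the effect of swapping the group cannot be separated from the effect of moving it. From the compounds shown here alone, it also remains open how a plain phenyl ring with no substituent, or a ring bearing a methoxy or an amino group, would read in this assay.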